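The source may hold more compounds than are shown below. What is called first, only, known or untested is meant among the compounds shown, and "the series" means these compounds.

Measured so far in an ADME assay on MT4 cells (Homo sapiens) for cytotoxicity; a higher number here means that more compound is tolerated, a lower number that less compound is tolerated:

Compound 1, `Cc1cc(C)cc(Cn2c(SCC(=O)Nc3ccccc3Cl)nc3ccc(Cl)cc32)c1`: in this assay compound 1 gives 141000 nM.
Compound 2, `Cc1cc(C)cc(S(=O)(=O)n2c(SCC(=O)Nc3ccccc3Cl)nc3ccc(Cl)cc32)c1`: in this assay compound 2 gives 99300 nM.
Compound 3, `Cc1cc(C)cc(Cn2c(SCC(=O)Nc3ccc(C)cc3Cl)nc3ccccc32)c1`: in this assay compound 3 gives 49200 nM.

Compound 4, `Cc1cc(C)cc(S(=O)(=O)n2c(SCC(=O)Nc3ccc(C)cc3Cl)nc3ccccc32)c1`, is not yet measured in this assay.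

The change from compound 1 to compound 2 is (3,5-dimethylphenyl)sulfonyl in place of 3,5-dimethylbenzyl on an aromatic nitrogen. The step it made, a 1.4-fold lower number from compound 1 to compound 2 (0.15 log units; within the scatter), lies within the scatter, so the two numbers are read as indistinguishable.

Compound 4 stands to compound 3 as compound 2 stands to compound 1: the change is (3,5-dimethylphenyl)sulfonyl in place of 3,5-dimethylbenzyl on an aromatic nitrogen, and the place is described in the same words, so it counts as the same change. How the core of compound 3 differs from the core of compound 1 is not broken down here; of compound 3 one can only say that its number is the lowest of the three and is beyond the scatter only against compound 1.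

For compound 4 the expected step is a 1.4-fold lower number from compound 3 to compound 4 (0.15 log units; within the scatter), which is put close to a 1.4-fold lower number from compound 1 to compound 2 (0.15 log units; within the scatter) because a 1.4-fold lower number from compound 1 to compound 2 (0.15 log units; within the scatter) came from the same change; this rests on one pair only. Compound 4 is accordingly estimated at 35000 nM, with a range from 15000 nM to 85000 nM.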

Compound 4, half-maximal cytotoxic concentration: 5400 nM
For compound 4 the middle estimate is 6.5-fold (0.81 log units) above the measured one; the whole stated range lies above it.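

In this assay, (3,5-dimethylphenyl)sulfonyl in place of 3,5-dimethylbenzyl on an aromatic nitrogen gives a 9.1-fold lower number from compound 3 to compound 4 (0.96 log units; beyond the scatter), so the step seen on the core of compound 1 does not carry over to the core of compound 3: the same change on two cores in this assay, a 1.4-fold lower number (0.15 log units; within the scatter) from compound 1 to compound 2 and a 9.1-fold lower number (0.96 log units; beyond the scatter) from compound 3 to compound 4, 6.4-fold (0.81 log units) apart, beyond the scatter of two such steps
For these two pairs, the size of the step depends on the core that carries the change, and a step read on one of these cores is a poor guide to the other. The two pairs do not show which feature of the two cores sets the gap, nor what size the step would take on any further core.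

It remains open which difference between the two cores accounts for the gap, and a core altered in only one of those places would separate them. Also open is how a carbonyl link or a longer carbon chain on the same aromatic nitrogen would compare with the two groups shown here.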